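The compounds below may be only part of what the source reports. "The series", "measured", "known", "first", "only" and "open" are said of these compounds alone.

Measured in a toxicity assay on HT-29 cells (Homo sapiens) for cytotoxicity; a higher number here means that more compound is tolerated, a lower number that less compound is tolerated:
compound 1 `CC(C)Cn1nc(C(=O)N[C@H]2COc3ccccc3N(C)C2=S)nc1Cc1ccccc1`: > 100000 nM (a limit)
compound 2 `CN1C(=S)[C@@H](NC(=O)c2nc(Cc3ccccc3)n(C3CCOCC3)n2)COc2ccccc21`: > 100000 nM (a limit)
compound 3 `CN1C(=S)[C@@H](NC(=O)c2nc(Cc3ccccc3)n(C3CCNC3)n2)COc2ccccc21`: > 100000 nM (a limit)

Compound 3 stands at > 100000 nM as a limit, not a number. Among the compounds with values here, it has no position above or below the other two compounds: the limit of > 100000 nM in this assay, at which 3 of the 3 values shown sit, sums up the series so far.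

Compound 4 `CN1C(=S)[C@@H](NC(=O)c2nc(Cc3ccccc3)n(Cc3ccccc3)n2)COc2ccccc21` differs from compound 3 as follows: benzyl in place of pyrrolidin-3-yl on an aromatic nitrogen.

Three measured steps change the group on this same nitrogen: a step that the two limits leave unreadable from compound 1 to compound 2 and a step that the two limits leave unreadable from compound 1 to compound 3 and a step that the two limits leave unreadable from compound 2 to compound 3 all bear on the change, yet none gives a size. Benzyl itself has not been measured on this nitrogen, so the expectation rests on these limits alone. No step beyond the scatter is expected in this assay and no direction can be read, with compound 3 at > 100000 nM as the starting limit. The expected change is a number no higher from compound 3 to compound 4 (the limit leaves the size open) as estimated here. Compound 4 is estimated at 100000 nM with an expected range from 30000 nM to 300000 nM and will probably be reported only as a limit.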

Compound 4, half-maximal cytotoxic concentration: > 100000 nM
Compound 4 was reported as a limit (the forecaster's own chance of this, stated with the estimate: 85%); the middle value sits exactly at the limit.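

Within the data shown here, compound 4 gives > 100000 nM in this assay, which is a limit, so no step linking compound 1, compound 2, compound 3 and compound 4 can be read. The series remains at a single ceiling: the limit of > 100000 nM in this assay, at which 4 of the 4 values shown sit.

The compounds shown leave open how much of each compound is tolerated, and whether the group on this aromatic nitrogen affects that at all.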